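The compounds below may be only part of what the source reports. "The series", "measured", "known", "first", "only" and "open" are said of these compounds alone.

Measured compounds:
Compound 1, `O=C(O)CC(CC1CCN(C(=O)CCc2ccc3c(n2)NCCC3)CC1)c1cccc(F)c1`: 1.7 h
Compound 2, `Cc1ncc(C(CC(=O)O)CC2CCN(C(=O)CCc3ccc4c(n3)NCCC4)CC2)cn1`: 2.6 h
Compound 3, `COc1ncc(C(CC(=O)O)CC2CCN(C(=O)CCc3ccc4c(n3)NCCC4)CC2)c(OC)n1`: "not determined" (no result reported)

In an in vivo ADME assay on the whole organism (Rattus norvegicus) for pharmacokinetics, at a dose of 10 mg/kg by the oral route (a higher number here means that the compound lasts longer, a lower number that the compound disappears faster), compound 1 gives 1.7 h. Among the measured compounds shown here, only two numbers exist, and compound 1 and compound 2 lie within the scatter of each other: compound 2 gives 2.6 h, and the step of a 1.5-fold higher number from compound 1 to compound 2 (0.18 log units; within the scatter) is within the scatter. Compound 3 carries no number in this assay.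

Compound 4, `O=C(O)CC(CC1CCN(C(=O)CCc2ccc3c(n2)NCCC3)CC1)c1ccc2ccccc2c1`, differs from compound 1 in a single place: naphthalen-2-yl in place of 3-fluorophenyl on a saturated chain carbon bound to two saturated chain carbons. For the measured compounds named here, the only measured step that touches the same position is the one from compound 1 to compound 2, which exchanged the same 3-fluorophenyl for another aromatic group and moved the half-life by a 1.5-fold higher number from compound 1 to compound 2 (0.18 log units; within the scatter), within the scatter. Going by the values given here, no measured step exchanges a 3-fluorophenyl for a naphthalen-2-yl, so the evidence bears on this change only loosely. The expectation is therefore a step of about no change at the digits printed from compound 1 to compound 4 (within the scatter) in this assay, that is, nothing beyond the scatter. For compound 4 the estimated half-life is 1.7 h, expected to fall between 0.8 h and 3.6 h.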

Compound 4, half-life: 5.65 h
Compound 4: the middle estimate sits 3.3-fold (0.52 log units) below what was measured; the whole stated range lies below it.
By their numbers in this assay, from the lowest: compounds 1 and 2 (each within the scatter of the next); then compound 4.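

In this assay, the group on this saturated chain carbon can shift the read-out beyond the usual scatter, which the earlier step at this position did not show. Naphthalen-2-yl gives a 3.3-fold higher number from compound 1 to compound 4 (0.52 log units; beyond the scatter) when it replaces 3-fluorophenyl, and a 2.2-fold higher number from compound 2 to compound 4 (0.34 log units; beyond the scatter) when it replaces 2-methylpyrimidin-5-yl, so the change stands out against both earlier groups, although both steps are modest. No measurement shown here explains this rise.

With only one group of two aromatic rings in the set, the compounds shown cannot separate the effect of the second ring from that of the added heavy atoms or the loss of the fluorine. A plain phenyl or a methoxy-substituted phenyl at the same carbon would help to tell these apart.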